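The source may report more compounds than this note shows. Statements on the series, on what has been measured and on what is new or still open speak of the compounds shown alone.

Of the compounds shown here, three sharing one core have been measured in a functional assay for agonist activity at 5-hydroxytryptamine receptor 4 (Homo sapiens), read by cAMP accumulation; on this read-out higher numbers stand for larger maximal responses and lower numbers for smaller maximal responses. Compound 1 `CS(=O)(=O)N1CCN(CC(O)CN2CCC(CNC(=O)c3cccc4[nH]c(C5CC5)nc34)CC2)CC1` carries a cyclopropyl group on an aromatic carbon and in this assay reaches 64%. Compound 2 `CCc1nc2c(C(=O)NCC3CCN(CC(O)CN4CCN(S(C)(=O)=O)CC4)CC3)cccc2[nH]1` carries an ethyl group at the same spot and reaches 22%. Compound 3 `CS(=O)(=O)N1CCN(CC(O)CN2CCC(CNC(=O)c3cccc4[nH]cnc34)CC2)CC1` carries only a hydrogen there and reaches 6%, the lowest of the three numbers, lying a number 58 percentage points lower from compound 1 to compound 3 (beyond the scatter) and a number 16 percentage points lower from compound 2 to compound 3 (beyond the scatter).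

Compound 4 `CC(C)(C)c1nc2c(C(=O)NCC3CCN(CC(O)CN4CCN(S(C)(=O)=O)CC4)CC3)cccc2[nH]1` differs from compound 3 in one place: tert-butyl in place of hydrogen on an aromatic carbon. Going by the values given here, two measured steps bear on this. Removing the cyclopropyl group gave a number 58 percentage points lower from compound 1 to compound 3 (beyond the scatter), and removing the ethyl group gave a number 16 percentage points lower from compound 2 to compound 3 (beyond the scatter); both times a carbon substituent at this position raised the maximal response, with the cyclopropyl case far larger than the ethyl case. A tert-butyl group has not been tried, so its size of effect is uncertain, but an increase beyond the scatter is expected. Compound 4 is therefore expected to give 35%, in a range of 8% to 75%, corresponding to an expected step of a number 29 percentage points higher from compound 3 to compound 4 (beyond the scatter).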

Compound 4, intrinsic activity: the largest response reached, in percent of the reference agonist's: 94%
For compound 4 the middle estimate is 59 percentage points below the measured one; the measured number lies above the stated range.
By their numbers in this assay, from the lowest: compound 3; then compound 2; then compound 1; then compound 4.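

At this carbon between two ring nitrogen atoms in this assay, the maximal response does not level off with the earlier groups: tert-butyl in place of hydrogen (a number 88 percentage points higher from compound 3 to compound 4 (beyond the scatter)) and tert-butyl in place of ethyl (a number 72 percentage points higher from compound 2 to compound 4 (beyond the scatter)) both give large gains. Tert-butyl in place of cyclopropyl (a number 30 percentage points higher from compound 1 to compound 4 (beyond the scatter)) adds a modest further gain, so compound 4 is the highest of the four, and a ring in this substituent is not needed for a high response. No measurement here explains why these groups differ so much.

Going by these compounds, whether the response would hold with a phenyl ring, an amine or a longer chain such as n-hexyl at this carbon remains open. Also open, on these data alone, is whether tert-butyl would give the same gain on a core with a different side chain.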